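Purine Hydroxamic-Free Benzamides: Swapping the Piperazine for an Anilino Group

This account rests on a few compounds, and the source may have more. Where it says the series, first, only, none or still open, it means among the compounds named here.

Compound 1: `CN1CCN(c2nc(Cl)nc3c2ncn3Cc2ccc(C(=O)Nc3ccccc3N)cc2)CC1` — 310 nM
Compound 2: `CCCCn1cnc2c(Nc3cccc(Cl)c3)nc(NCOCc3ccc(C(=O)Nc4ccccc4N)cc3)nc21` — 2120 nM

Going by the values given here, in a functional assay on HCT-116 cells (Homo sapiens) for antiproliferative activity, read by CCK-8 assay, with a stated time of 72 h (on this read-out higher numbers stand for weaker inhibition and lower numbers for stronger inhibition), compound 1 gives 310 nM, the lower of the two numbers measured so far. Compound 2 gives 2120 nM in this assay, a higher number than compound 1, and the gap lies beyond the usual scatter. Among the compounds with values here, compound 2 differs from compound 1 in several places at once, so the two values show only that the pair sits apart.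

Compound 3, `Nc1ccccc1NC(=O)c1ccc(Cn2cnc3c(Nc4cccc(Cl)c4)nc(Cl)nc32)cc1`, has not yet been measured. It differs from compound 1 in one place: (3-chlorophenyl)amino in place of 4-methylpiperazin-1-yl on an aromatic carbon. Within the data shown here, no single-change step between measured compounds exists to guide this change. Among the measured compounds shown here, the only measured compound that carries a (3-chlorophenyl)amino group, compound 2, gives 2120 nM, but it differs from compound 1 in other places as well, so the step in this assay for compound 3 is uncertain and is expected to be modest, if any, in the direction of a higher number. Compound 3 is estimated at 500 nM, within 150 nM to 1800 nM, an expected step of a 1.6-fold higher number from compound 1 to compound 3 (0.21 log units; within the scatter).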

Compound 3, half-maximal inhibitory concentration: 2340 nM
Compound 3: the middle estimate sits 4.7-fold (0.67 log units) below what was measured; the whole stated range lies below it.
By their numbers in this assay, from the lowest: compound 1; then compounds 2 and 3 (each within the scatter of the next).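

In this assay the exchange of 4-methylpiperazin-1-yl for (3-chlorophenyl)amino on this aromatic carbon gives a 7.5-fold higher number from compound 1 to compound 3 (0.88 log units; beyond the scatter) and provides the first single-change step among these compounds. With the rest of the structure held fixed, it shows that this carbon, next to the ring nitrogen and meta to a chloro group, does not tolerate every substituent equally in this assay. No measurement shown here bears on why the number rises.

On these data alone, it remains open whether the step follows from removing the six-membered non-aromatic ring or from introducing the 3-chlorophenyl group, a question that morpholine, piperidine or an unsubstituted phenylamino group at this carbon could address. As far as these compounds go, it is also open whether the step would stay the same if an amine replaced the chloro group on the core.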